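The source may hold more compounds than are shown below. What is called first, only, known or untested is meant among the compounds shown, and "the series" means these compounds.

Measured so far:
- compound 1, `O=C(CSc1nc2ccc(NC(=O)CCl)cc2s1)NCc1ccccc1`: 1100 nM
- compound 2, `O=C(CSc1nc2ccc(NC(=O)c3ccccc3)cc2s1)NCc1ccccc1`: 34200 nM
- compound 3, `COc1ccccc1C(=O)Nc1ccc2nc(SCC(=O)NCc3ccccc3)sc2c1`: 8000 nM

In a functional assay on HepG2 cells (Homo sapiens) for cytotoxicity, read by MTT assay, with a stated time of 48 h (on this read-out higher numbers stand for weaker inhibition and lower numbers for stronger inhibition), compound 3 has the second highest number of the three: compound 2 is above it by a 4.3-fold lower number from compound 2 to compound 3 (0.63 log units; beyond the scatter) in reverse, and compound 1 is below it by a 7.3-fold higher number from compound 1 to compound 3 (0.86 log units; beyond the scatter) in reverse. Compound 4, `O=C(CSc1nc2ccc(NC(=O)c3ccc(Cl)cc3)cc2s1)NCc1ccccc1`, is not yet measured; it differs from compound 3 by 4-chlorophenyl in place of 2-methoxyphenyl on a carbonyl carbon.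

Going by the values given here, two measured steps bear on this change. The step from compound 1 to compound 2 was a 31-fold higher number from compound 1 to compound 2 (1.49 log units; beyond the scatter), and the step from compound 1 to compound 3 was a 7.3-fold higher number from compound 1 to compound 3 (0.86 log units; beyond the scatter), so both aryl groups on the carbonyl carbon gave higher numbers than chloromethyl, with the methoxy-bearing one less so. The step from compound 2 to compound 3, a 4.3-fold lower number from compound 2 to compound 3 (0.63 log units; beyond the scatter), shows that removing the methoxy is likely to push the number back up toward that of compound 2. Among the compounds with values here, no measured pair speaks to the chlorine that enters. For compound 4 a rise is therefore expected, about a 3.1-fold higher number from compound 3 to compound 4 (0.49 log units; beyond the scatter), giving an estimate of 25000 nM with a range from 8000 nM to 70000 nM.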

Compound 4, half-maximal inhibitory concentration: 25400 nM
Compound 4: middle estimate off by 1.0-fold (0.01 log units), on the low side; the range from low to high includes it.
By their numbers in this assay, from the lowest: compound 1; then compound 3; then compounds 4 and 2 (each within the scatter of the next).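

In this assay, the chloro in place of hydrogen on the aromatic carbon gives a 1.3-fold lower number from compound 2 to compound 4 (0.13 log units; within the scatter), so this substituent on the phenyl group leaves the number indistinguishable from that of the unsubstituted benzamide. The lower number seen with 2-methoxyphenyl is therefore not shared by every substituted phenyl group here, as the swap to 4-chlorophenyl gives a 3.2-fold higher number from compound 3 to compound 4 (0.50 log units; beyond the scatter). Chloromethyl on the carbonyl carbon also keeps its clear lead over this third aryl group, at a 23-fold higher number from compound 1 to compound 4 (1.36 log units; beyond the scatter), and all three aryl compounds have higher numbers than compound 1.

No measurement shown offers a reason for these differences. Going by these compounds, it remains open whether the gap reflects the substituent or where it sits, which 2-chlorophenyl could help separate, and whether a plain methyl in place of chloromethyl would keep the low number.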